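A few compounds are considered here, and "the series" means these few. Any claim that something is new, unique, unknown or untested is made for them only; others in the source may bear on it.

Among the compounds with values here, compound 1 `O=C(Nc1ccc(S(=O)(=O)Nc2cccc(Cl)c2)cc1)c1ccc(Cl)cc1Cl` is the only member of this series with a number in hand. In a functional assay on HEK293 cells for agonist activity at probable G-protein coupled receptor 27 (Homo sapiens), read by a luciferase reporter and beta-arrestin recruitment, with a stated time of 10 min (on this read-out lower numbers stand for smaller maximal responses and higher numbers for larger maximal responses), compound 1 gives 40%, a moderate maximal response relative to the reference. Compound 2 `Cc1ccc(NS(=O)(=O)c2ccc(NC(=O)c3ccc(Cl)cc3Cl)cc2)cc1` shares the same core but carries a different group on the sulfonamide nitrogen; in this assay compound 2 gives "not determined" (no result reported), so it stands without a number of its own and cannot be placed against compound 1.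

The step under consideration leads from compound 2 to compound 3 `O=C(Nc1ccc(S(=O)(=O)Nc2ccccc2Cl)cc1)c1ccc(Cl)cc1Cl`, where the change is 2-chlorophenyl in place of 4-methylphenyl on a sulfonamide nitrogen. Within the data shown here, with no measured pair of compounds differing in a single place, the size and direction of this step cannot be read from the data; in this assay one can only expect a change within the scatter or, at most, a modest shift, since the closest point of reference, compound 1, sits at 40% with a chlorophenyl of its own on the sulfonamide nitrogen. Compound 3 is therefore estimated to reach about 38%, with a plausible range from 12% to 65%.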

Compound 3, largest response reached (Emax), in percent of the reference or control that the assay uses: 53%
Compound 3: middle estimate off by 15 percentage points, on the low side; the measured number falls inside the stated range.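

Within the data shown here, for the first time there is a readable step at the sulfonamide nitrogen: in this assay, with the rest of the structure unchanged, 2-chlorophenyl in place of 3-chlorophenyl gives a number 13 percentage points higher from compound 1 to compound 3 (beyond the scatter) on the largest response reached. Carrying a chlorophenyl on this nitrogen therefore does not fix the response on its own, since the place of the chlorine on that phenyl ring separates the two compounds by more than the usual scatter, though only modestly. No measured information at hand accounts for this difference.

On these data alone, compound 2 has no number, so the step away from its 4-methylphenyl cannot be read, and whether a methyl or a chlorine on this ring gives the larger response stays unknown. Among these compounds, with only two measured groups at this position, it also remains open how 4-chlorophenyl, plain phenyl, 2-methylphenyl or a benzyl group on the same nitrogen would compare, and whether the higher response seen with 2-chlorophenyl would hold for other groups in that place on the ring.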